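Replacing an Aromatic Ring with an Open Chain

A few compounds are considered here, and "the series" means these few. Any claim that something is new, unique, unknown or untested is made for them only; others in the source may bear on it.

Going by the values given here, in an assay on isolated protein for inhibition of Amine oxidase [flavin-containing] B (Homo sapiens), read by fluorescence (a lower number here means a stronger inhibitor, a higher number a weaker inhibitor), compound 2 `COc1cccc(-c2csc(N/N=C/c3cccs3)n2)c1` gives 494 nM, the higher of the two numbers measured so far, while compound 1 `COc1cccc(-c2csc(N/N=C3\CCC(C)C3)n2)c1` gives 231 nM. Compound 3 `CCC(CC)=NNc1nc(-c2cccc(OC)c2)cs1` differs from compound 2 by a group of 6 heavy atoms (5 carbon, 1 nitrogen; no ring) in place of a group of 7 heavy atoms (5 carbon, 1 nitrogen, 1 sulfur; one five-membered aromatic ring with 1 hetero atom), on a nitrogen on an aromatic ring. Among the compounds with values here, the only measured step bearing on this position is a 2.1-fold higher number from compound 1 to compound 2 (0.33 log units; beyond the scatter). Because a 2.1-fold higher number from compound 1 to compound 2 (0.33 log units; beyond the scatter) accompanied the exchange of a non-aromatic ring for an aromatic one, moving instead to an open-chain group is expected to lower the number by a modest amount. Compound 3 is therefore expected to give 300 nM, between 120 nM and 800 nM, which means an expected 1.6-fold lower number from compound 2 to compound 3 (0.22 log units; within the scatter).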

Compound 3, half-maximal inhibitory concentration: 772 nM
Estimate against measurement, compound 3: 2.6-fold (0.41 log units) below; the measured number falls inside the stated range.
By their numbers in this assay, from the lowest: compound 1; then compounds 2 and 3 (each within the scatter of the next).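

In this assay the open-chain group of compound 3 cannot be told apart from the five-membered aromatic ring of compound 2 (a 1.6-fold higher number from compound 2 to compound 3 (0.19 log units; within the scatter)). The open chain does separate from the five-membered non-aromatic ring (a 3.3-fold higher number from compound 1 to compound 3 (0.52 log units; beyond the scatter)), so on this nitrogen only the carbon ring of compound 1 stands clear of another group, and only of the open chain. The compounds shown leave open whether a cyclohexyl ring or an unsubstituted cyclopentyl ring would match compound 1, and whether a longer chain would differ from the open chain of compound 3. No evidence bearing on this result is available.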